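Ester to amide on the dienoate chain: compound 3

The source may hold more compounds than are shown below. What is called first, only, known or untested is meant among the compounds shown, and "the series" means these compounds.

Measured so far:
compound 1 `C=CCOC(=O)/C=C(C)/C=C/CC(C)CCCC(C)C`: 6.73
compound 2 `C=CCOC(=O)/C=C(C)/C=C/CC(C)CCCC(C)(C)OC`: 5.53

In a physicochemical assay for lipophilicity (a lower number here means a more polar compound, a higher number a more lipophilic compound), compound 1 gives the higher of the two numbers, compound 2 standing a number 1.20 log units lower from compound 1 to compound 2 (beyond the scatter). Compound 3 `CC(/C=C/CC(C)CCCC(C)C)=C\C(=O)NCC(C)C` differs from compound 1 as follows: isobutylamino in place of allyloxy on a carbonyl carbon. Among the measured compounds shown here, the only measured step, methoxy in place of hydrogen, is a change of a different kind, so no measured step bears directly on this one. A modest drop is nevertheless expected, a number 0.73 log units lower from compound 1 to compound 3 (beyond the scatter). For compound 3 the expected value in this assay is 6, with a range from 5.4 to 6.6.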

Compound 3, partition coefficient: 6.19
Beside the measured number, compound 3's estimate is 0.19 log units below it; low and high end bracket the measured number.
By their numbers in this assay, from the lowest: compound 2; then compound 3; then compound 1.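

In this assay, the carbonyl carbon of the dienoate chain accepts isobutylamino in place of allyloxy with only a modest shift, a number 0.54 log units lower from compound 1 to compound 3 (beyond the scatter). Among the compounds shown here, this is the first reading at this end of the chain, where the entering group counts a hydrogen-bond donor and the leaving group a hydrogen-bond acceptor. No measurement at hand gives a reason for the step.

As far as these compounds go, whether the shift follows the nitrogen link or the isobutyl chain stays open; allylamino and isobutoxy on the same carbonyl carbon would separate the two. From the compounds shown here alone, whether the methoxy step carries over to the amide is also open.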